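The compounds below may be only part of what the source reports. "The series", "measured", "known", "first", "only" and "open" are said of these compounds alone.

Measured so far:
- compound 1 `COc1cc(OC)c(/C=C/S(=O)(=O)Cc2ccc([N+](=O)[O-])cc2)c(OC)c1`: 15000 nM
- compound 2 `COc1ccc(CS(=O)(=O)/C=C/c2ccccc2OC)cc1`: 3500 nM
- compound 3 `COc1ccc(CS(=O)(=O)/C=C/c2cc(OC)cc(OC)c2)cc1`: > 20000 nM

In a functional assay on DU-145 cells (Homo sapiens) for antiproliferative activity, read by trypan blue exclusion (a lower number here means a stronger inhibitor, a higher number a weaker inhibitor), compound 1 gives 15000 nM, the highest of the two numbers in the set. Among the measured compounds shown here, compound 2 gives the only other number, 3500 nM, a lower value that lies beyond the scatter of the assay. For compound 3 the assay reports only a limit, > 20000 nM, and no number; this is the case described by the limit of > 20000 nM in this assay, at which 1 of the 3 values shown sits.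

The step from compound 1 to compound 4 `COc1ccc(CS(=O)(=O)/C=C/c2c(OC)cc(OC)cc2OC)cc1` is a single change: methoxy in place of nitro on an aromatic carbon. For the measured compounds named here, no measured pair of compounds shares this change, so its size is not known from the set. The step is expected to be small, within the scatter or slightly towards a weaker inhibitor, because compound 1 already sits near the region where compound 3 gave only the limit > 20000 nM. For compound 4 the estimate in this assay is 12000 nM, with a range from 3000 nM to 20000 nM. This estimate corresponds to an expected step of a 1.3-fold lower number from compound 1 to compound 4 (0.10 log units; within the scatter). A reading that is only a limit is a real possibility for compound 4, given that compound 3 gave one.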

Compound 4, half-maximal inhibitory concentration: 25 nM
Compound 4: middle estimate off by 480-fold (2.68 log units), on the high side; measured number below the stated range.
By their numbers in this assay, from the lowest: compound 4; then compound 2; then compound 1. At a limit, above all of these: compound 3.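

In this assay, the aromatic carbon para to a large group proves highly sensitive to what it carries: putting methoxy in place of nitro gives a 600-fold lower number from compound 1 to compound 4 (2.78 log units; beyond the scatter), a change beyond the scatter. Among the compounds shown here, this is the first step in the set that differs in one place, so the earlier compounds could show no effect of this position or of this change, only unconnected values. Nothing shown bears on why the step is so large.

On these data alone, it remains open whether the step reflects the presence of methoxy or the absence of nitro, and how an amine, a hydroxyl or a longer alkoxy chain would read at the same position. As far as these compounds go, it also remains open whether a step of this size would recur with the methoxy groups of the other aromatic ring arranged differently.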